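Furan-2-yl to pyridin-2-yl in the morpholine sulfonyl series

This account rests on a few compounds, and the source may have more. Where it says the series, first, only, none or still open, it means among the compounds named here.

Measured in a functional assay on SMMC-7721 cells (Homo sapiens) for antiproliferative activity, read by MTT assay, with a stated time of 72 h (on this read-out higher numbers stand for weaker inhibition and lower numbers for stronger inhibition), so far
Compound 1 `C/C(=N\NC(=O)c1cccc(S(=O)(=O)N2CCOCC2)c1)c1ccc(F)cc1` gives > 100000 nM, which is a limit
Compound 2 `C/C(=N\NC(=O)c1cccc(S(=O)(=O)N2CCOCC2)c1)c1cccc(N)c1O` gives 2330 nM
Compound 3 `O=C(N/N=C/c1ccco1)c1cccc(S(=O)(=O)N2CCOCC2)c1` gives > 100000 nM, which is a limit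

Compound 3 has no number of its own and sits at the limit of > 100000 nM in this assay, at which 2 of the 3 values shown sit. The next compound is compound 4 `O=C(N/N=C/c1ccccn1)c1cccc(S(=O)(=O)N2CCOCC2)c1`, and the change is pyridin-2-yl in place of furan-2-yl on a carbon with a double bond to nitrogen. In words, pyridin-2-yl stands in place of furan-2-yl on a carbon with a double bond to nitrogen.

Among the measured compounds shown here, the only measured step is an at least 42-fold lower number from compound 1 to compound 2 (1.63 log units; beyond the scatter), which is large and beyond the scatter. It puts 3-amino-2-hydroxyphenyl in place of 4-fluorophenyl, so it involves neither group of the present change and sets no size for it. For the measured compounds named here, no step between furan-2-yl and pyridin-2-yl has been measured.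

No step beyond the scatter is therefore expected in this assay. The expectation starts from compound 3, whose value > 100000 nM is a limit. The expected step is an at least 1.2-fold lower number from compound 3 to compound 4 (0.09 log units; that floor lies within the scatter), and this is only an estimate. The estimated value for compound 4 is 80000 nM, with an expected range from 20000 nM to 150000 nM, and a reading at the limit would not be a surprise.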

Compound 4, half-maximal inhibitory concentration: > 100000 nM
Compound 4 gave a limit, no number; the forecaster's own chance of this, stated with the estimate: 60%; at least 1.2-fold (0.09 log units) between middle value and limit.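

In this assay compound 4 gives > 100000 nM, which is a limit. Compound 3 gives > 100000 nM, also a limit, and no step can be read from this pair. The compounds shown leave open whether pyridin-2-yl and furan-2-yl differ at all in this assay.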